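This account rests on a few compounds, and the source may have more. Where it says the series, first, only, none or still open, it means among the compounds named here.

Compound 2, `CCN(CC)S(=O)(=O)c1ccc(S(=O)(=O)N2CCC[C@@H](C(=O)N3CCS(=O)(=O)CC3)C2)cc1`, is the weakest inhibitor among the three compounds measured in a functional assay on BXPC-3 cells (Homo sapiens) for inhibition, read by MTT assay, with a stated time of 7 days; on this read-out lower numbers stand for stronger inhibition and higher numbers for weaker inhibition: compound 2 gives 4430 nM. Compound 1, `O=C([C@@H]1CCCN(S(=O)(=O)c2ccc(S(=O)(=O)C3CCC3)cc2)C1)N1CCC(F)(F)CC1`, gives 78 nM, and compound 3, `CC(C)CS(=O)(=O)c1ccc(S(=O)(=O)N2CCC[C@@H](C(=O)N3CCC(F)(F)CC3)C2)cc1`, gives 311 nM. Compound 2 differs from each of these in two places at once, so their gaps cannot be pinned on a single change.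

Compound 4, `CCN(CC)S(=O)(=O)c1ccc(S(=O)(=O)N2CCC[C@@H](C(=O)N3CCC(COC)CC3)C2)cc1`, differs from compound 2 in one place: 4-(methoxymethyl)piperidin-1-yl in place of 1,1-dioxothiomorpholin-4-yl on a carbonyl carbon. Going by the values given here, no measured step touches this position. Among the compounds with values here, the only single-change step known, a 4.0-fold higher number from compound 1 to compound 3 (0.60 log units; beyond the scatter), concerns the group on the sulfonyl sulfur and does not bear on the amide. The two compounds carrying a piperidine-type amide, compounds 1 and 3, sit far below compound 2, which hints weakly that an amide of that kind may help, though the sulfonyl group also differs there.

A modest fall in the number is therefore expected for compound 4, a 3.0-fold lower number from compound 2 to compound 4 (0.47 log units; beyond the scatter), with wide uncertainty. Compound 4 is estimated at 1500 nM, between 400 nM and 6000 nM.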

Compound 4, half-maximal inhibitory concentration: 1360 nM
Beside the measured number, compound 4's estimate is 1.1-fold (0.04 log units) above it, within the range that was stated.
By their numbers in this assay, from the lowest: compound 1; then compound 3; then compound 4; then compound 2.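

Going by these compounds alone, this is the first step measured at the amide, and it shows that this position matters on its own: in this assay, putting 4-(methoxymethyl)piperidin-1-yl in place of 1,1-dioxothiomorpholin-4-yl on a carbonyl carbon, with the rest of the molecule unchanged, gives a 3.3-fold lower number from compound 2 to compound 4 (0.51 log units; beyond the scatter). The step is modest but beyond the scatter, so the amide group alone shifts the number in this cell assay. No measurement here explains why the number falls.

The swap changes the ring and adds a methoxymethyl chain at once, so a plain piperidin-1-yl or a morpholin-4-yl on the same carbonyl carbon would be needed to separate those two parts. Also open, from the compounds shown here alone, is how the amide carried by compound 1 and compound 3 would behave with the rest of compound 4.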